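A Furan Ring Replaces the Hydroxyphenyl Arm

The source may report more compounds than this note shows. Statements on the series, on what has been measured and on what is new or still open speak of the compounds shown alone.

Measured so far in a functional assay on HT-29 cells (Homo sapiens) for inhibition, read by sulforhodamine B assay, with a stated time of 48 h; a lower number here means a stronger inhibitor of growth, a higher number a weaker inhibitor of growth:
compound 1 `CC1=CC[C@H](C(C)(C)NC(=S)N/N=C/c2ccccc2O)CC1`: 16600 nM
compound 2 `CC1=CC[C@H](C(C)(C)NC(=S)N/N=C/c2ccc(N(C)C)cc2)CC1`: > 100000 nM, a limit of the assay rather than a number
compound 3 `CC1=CC[C@H](C(C)(C)NC(=S)N/N=C/c2ccccc2[N+](=O)[O-])CC1`: 70800 nM

Compound 1 stands lowest of the two numbers shown; its nearest neighbour is compound 3, reached by the step of a 4.3-fold higher number from compound 1 to compound 3 (0.63 log units; beyond the scatter). Compound 2 reaches only the limit described by the limit of > 100000 nM in this assay, at which 1 of the 3 values shown sits.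

Compound 4 `CC1=CC[C@H](C(C)(C)NC(=S)N/N=C/c2ccco2)CC1` differs from compound 1 in one place: furan-2-yl in place of 2-hydroxyphenyl on a carbon with a double bond to nitrogen. Within the data shown here, no measured step exchanges the whole ring; the only measured step at this end of the molecule, a 4.3-fold higher number from compound 1 to compound 3 (0.63 log units; beyond the scatter), swapped a substituent on the same six-membered ring and raised the number modestly. Since the incoming furan-2-yl brings no hydrogen-bond donor and is a smaller ring, a modest rise in number beyond the scatter is expected here as well, though with wide uncertainty.

For compound 4 the estimated value is 35000 nM, with an expected range from 12000 nM to 100000 nM. The expected step is a 2.1-fold higher number from compound 1 to compound 4 (0.32 log units; beyond the scatter).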

Compound 4, concentration for total growth inhibition: 26900 nM
Beside the measured number, compound 4's estimate is 1.3-fold (0.11 log units) above it, within the range that was stated.
By their numbers in this assay, from the lowest: compounds 1 and 4 (each within the scatter of the next); then compound 3. At a limit, above all of these: compound 2.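

In this assay, exchanging the whole ring at this position gives a 1.6-fold higher number from compound 1 to compound 4 (0.21 log units; within the scatter), whereas the earlier step at this end of the molecule changed only a substituent on the six-membered ring. The 2-hydroxyphenyl group, with its hydrogen-bond donor, is therefore not needed to keep the number at this level, as the furan-2-yl group, which has no donor, stays within the scatter of it. No measured property in the data at hand bears on this step, so the result stands without an explanation.

The compounds shown leave open whether a thiophene or pyridine ring on this carbon would keep the number, and whether an amine or a methyl group on the furan-2-yl ring would shift it. On these data alone, all of them also share the same remaining core, so how a change elsewhere in it would act remains unknown.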